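Compound 1 to compound 3: removing the chain methyl

This account rests on a few compounds, and the source may have more. Where it says the series, first, only, none or still open, it means among the compounds named here.

In an ADME assay on Huh-7 cells (Homo sapiens) for cytotoxicity, read by a luciferase reporter and MTT assay, with a stated time of 72 h (on this read-out higher numbers stand for lower toxicity in this test and lower numbers for higher toxicity in this test), compound 1 `COc1cc(/C=N/NC(=O)C(C)Oc2ccc([N+](=O)[O-])cc2)ccc1OC(=O)c1sc2ccccc2c1Cl` gives > 125000 nM, which is a limit of the assay and not a number. Compound 2 `CCOc1cc(/C=N/NC(=O)C(C)Oc2ccc([N+](=O)[O-])cc2)ccc1OC(=O)c1ccc(Cl)cc1Cl` gives > 125000 nM, also a limit, so both values shown sit at the limit of > 125000 nM in this assay, at which 2 of the 2 values shown sit. Compound 3 `COc1cc(/C=N/NC(=O)COc2ccc([N+](=O)[O-])cc2)ccc1OC(=O)c1sc2ccccc2c1Cl` has hydrogen in place of methyl on a saturated chain carbon bound to a carbonyl carbon and an oxygen on an aromatic ring. For the measured compounds named here, no measured step is available to size this change. In this assay, the expected step of a number no higher from compound 1 to compound 3 (the limit leaves the size open) is none beyond the scatter, with no direction expected. The estimated value for compound 3 is 125000 nM, within an expected range of 60000 nM to 250000 nM.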

Compound 3, half-maximal cytotoxic concentration: > 125000 nM
Compound 3: no number, only a limit; the forecaster's own chance of this, stated with the estimate: 70%; the middle value lies on the limit itself.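

Compound 1 and compound 3 both sit at a limit of the assay, not a number, so no step can be read between them: the limit of > 125000 nM in this assay, at which 3 of the 3 values shown sit.

The compounds shown leave open whether hydrogen in place of methyl changes the read-out at all.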